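The compounds below may be only part of what the source reports. "The series", "measured", "known", "first", "only" and "open" are said of these compounds alone.

Among the compounds with values here, in an ADME assay (liver) for metabolic stability, with Liver microsome (Rattus norvegicus) as the target, read by LC-MS, using microsomes and NADPH, with stated times of 5 min and 60 min, tested at 4 uM (a lower number here means that less of the compound is left, a higher number that more of the compound is left), compound 3 `Cc1c(OCCCCOc2ccc(C(=O)O)cc2F)ccc(C(=O)CC2CCCC2)c1O` gives 66%, the highest of the three numbers measured so far. Compound 1 `Cc1cc(C(=O)O)ccc1OCCCCOc1ccc(C(=O)CC(C)C)c(O)c1C` stands at 41% and compound 2 `Cc1c(OCCCCOCOc2ccc(C(=O)O)cc2)ccc(C(=O)CC2CCCC2)c1O` at 31%. Compound 4 `Cc1c(OCCCCOc2ccc(C(=O)O)cc2F)ccc(C(=O)CC(C)C)c1O` keeps the rest of compound 3 but carries isopropyl in place of cyclopentyl on a saturated chain carbon bound to a carbonyl carbon. Within the data shown here, no measured pair isolates this exchange. Among the measured compounds shown here, the one measured step, a number 35 percentage points higher from compound 2 to compound 3 (beyond the scatter), is large but concerns another part of the molecule, so it shows how far this read-out can move, not what this exchange does. Compound 1 carries the same isopropyl and reads 41%, but it differs from compound 4 elsewhere too, so it points only weakly towards a lower number. In this assay, the expected step is a number 8 percentage points lower from compound 3 to compound 4 (within the scatter), a modest fall that would stay within the scatter. Compound 4 is estimated at 58%, with an expected range from 40% to 75%.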

Compound 4, percent of the compound remaining: 57%
Beside the measured number, compound 4's estimate is 1 percentage points above it; low and high end bracket the measured number.
By their numbers in this assay, from the lowest: compounds 2 and 1 (each within the scatter of the next); then compounds 4 and 3 (each within the scatter of the next).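

In this assay, isopropyl in place of cyclopentyl on a saturated chain carbon bound to a carbonyl carbon gives a number 9 percentage points lower from compound 3 to compound 4 (within the scatter), so this first direct reading of the exchange shows that the open group can stand in for the ring in this pair without a step beyond the scatter. Fluoro in place of methyl on an aromatic carbon, with isopropyl kept, gives a number 16 percentage points higher from compound 1 to compound 4 (beyond the scatter), and of the two exchanges only this one lies beyond the scatter. The data offer no explanation for either step.

The compounds shown leave open whether cyclohexyl or a chain ending in an amine on that saturated chain carbon would read like cyclopentyl and isopropyl. They also leave open whether chloro on the aromatic carbon would match fluoro, and whether the fluoro step holds with cyclopentyl.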